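This account rests on a few compounds, and the source may have more. Where it says the series, first, only, none or still open, it means among the compounds named here.

Measured compounds:
- Compound 1, `O=C(C/C=C/c1cccc(Cl)c1)Nc1nc2ccccc2c(=O)s1`: 11.4 nM
- Compound 2, `O=C(CCc1ccccc1)Nc1nc2ccccc2c(=O)s1`: 422 nM

In an assay on membranes from brain for displacement of a labelled ligand from adenosine receptor A1 (Rattus norvegicus), read by scintillation counting, with a stated time of 90 min (on this read-out lower numbers stand for stronger inhibition and higher numbers for weaker inhibition), compound 2 gives 422 nM and so stands with the highest number of the two measured compounds. For the measured compounds named here, its nearest neighbour on this read-out is compound 1, which in this assay gives 11.4 nM, a far lower number that lies well beyond the scatter; the two structures differ in more than one place, so no single step between them is counted here.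

Compound 3, `O=C(CCc1ccc(Cl)c(Cl)c1)Nc1nc2ccccc2c(=O)s1`, has not yet been measured in this assay. It is reached from compound 2 by one change: 3,4-dichlorophenyl in place of phenyl on a saturated chain carbon, two bonds along the chain from a carbonyl carbon. Going by the values given here, no step of this kind is available among the measured compounds, so the size of the step is open. Among the compounds with values here, the writer expects a moderate drop in the number, and no rise beyond the scatter, because the only other measured compound, compound 1, with a chlorine-bearing ring, gives 11.4 nM. The expected step from compound 2 to compound 3 is a 3.8-fold lower number from compound 2 to compound 3 (0.58 log units; beyond the scatter). Compound 3 is estimated at 110 nM, within a range from 30 nM to 400 nM.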

Compound 3, inhibition constant: > 1500 nM
Compound 3 gave a limit, no number (the forecaster's own chance of this, stated with the estimate: 3%); at least 13-fold (1.13 log units) between middle value and limit.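

Setting 3,4-dichlorophenyl in place of phenyl on a saturated chain carbon, two bonds along the chain from a carbonyl carbon, gives an at least 3.5-fold higher number from compound 2 to compound 3 (0.55 log units; beyond the scatter) in this assay, so at this position the change weakens inhibition rather than strengthening it. Compound 3 gives only a limit of the assay and not a number, so the step has a lower bound but no measured size: the limit of > 1500 nM in this assay, at which 1 of the 3 values shown sits. Compound 1 also carries a chlorine-bearing ring, but it differs from compound 3 in more than one place, so this step is the only one shown that isolates a change on the ring.

The compounds shown leave open whether a single chlorine on the phenyl ring of this saturated chain would act as the two chlorines do, or whether a methoxy group or a longer chain would fare differently at this place. They also leave open how 3,4-dichlorophenyl would behave on the unsaturated chain of compound 1.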